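Removing a tert-butyl group from two nucleoside cores

A few compounds are considered here, and "the series" means these few. Any claim that something is new, unique, unknown or untested is made for them only; others in the source may bear on it.

Compound 1 `CC(=O)OC[C@H]1O[C@@H](n2cc(-c3cc(-c4ccc(C(C)(C)C)cc4)no3)c(=O)[nH]c2=O)C[C@@H]1OC(C)=O`: 74.7%
Compound 2 `CC(=O)OC[C@H]1O[C@@H](n2cc(-c3cc(-c4ccccc4)no3)c(=O)[nH]c2=O)C[C@@H]1OC(C)=O`: 97.6%
Compound 3 `CC(C)(C)c1ccc(Cn2cc(-c3cn([C@H]4C[C@H](O)[C@@H](CO)O4)c(=O)[nH]c3=O)nn2)cc1`: 102%

In a functional assay on ACHN cells (Homo sapiens) for cytotoxicity, read by sulforhodamine B assay, tested at 10 uM (on this read-out lower numbers stand for less inhibition and higher numbers for more inhibition at the one concentration tested (going by the name of the read-out)), compound 1 gives 74.7% and compound 2 gives 97.6%. The change between them, (hydrogen in place of tert-butyl on an aromatic carbon), gave a number 22.9 percentage points higher from compound 1 to compound 2 (beyond the scatter). The core of compound 3 differs from that of compound 1 in a way not broken down here; compound 3 gives 102%, and its value and that of compound 2 lie within the scatter of each other. Compound 4 `O=c1[nH]c(=O)n([C@H]2C[C@H](O)[C@@H](CO)O2)cc1-c1cn(Cc2ccccc2)nn1` is not yet measured; it carries the same change, (hydrogen in place of tert-butyl on an aromatic carbon), on the core of compound 3. Because compound 3 already stands at 102%, there is little room for a rise, so a step of about a number 2 percentage points lower from compound 3 to compound 4 (within the scatter) is expected in this assay. Compound 4 is estimated at 100%, between 88% and 108%.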

Compound 4, a percentage reported as inhibition, at one concentration (the size of the read-out at that concentration, not a potency): 98.7%
Compound 4: middle estimate off by 1.3 percentage points, on the high side, within the range that was stated.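

On the core of compound 3, the change from 4-(tert-butyl)phenyl to phenyl gave a number 3.3 percentage points lower from compound 3 to compound 4 (within the scatter) in this assay, so the rise seen on the core of compound 1 did not carry over. The two steps differ: the same change on two cores in this assay, a number 22.9 percentage points higher (beyond the scatter) from compound 1 to compound 2 and a number 3.3 percentage points lower (within the scatter) from compound 3 to compound 4, 26.2 percentage points apart, beyond the scatter of two such steps. This shows that the size of the step is not transferable between these two cores, but it does not show why, and with compound 3 already at 102% the read-out left little room for any rise.

The compounds shown leave open how an amine, a carboxylic acid or a longer chain in place of the tert-butyl group would read on either core. They also leave open whether the two cores would still differ at a lower test concentration.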